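From Compound 3 to Compound 4: Fluoro in Place of Methoxy

The source may report more compounds than this note shows. Statements on the series, on what has been measured and on what is new or still open speak of the compounds shown alone.

Compound 1 `COc1ccccc1N1CCN(CCCCNC(=O)C(C)(C)C)CC1` — in an assay on HEK293 cells for binding affinity to D(4) dopamine receptor (Homo sapiens), read by radioligand binding (on this read-out lower numbers stand for stronger inhibition and higher numbers for weaker inhibition), compound 1 gives 12.6 nM
Compound 2 `CC(C)(C)C(=O)NCCCCN1CCN(c2ccc(Cl)cc2)CC1` — in this assay compound 2 gives 12.6 nM
Compound 3 `COc1ccc(N2CCN(CCCCNC(=O)C(C)(C)C)CC2)cc1` — in this assay compound 3 gives 316 nM

Among the compounds with values here, compound 3 stands highest of the three numbers measured so far. The steps of a 25-fold higher number from compound 1 to compound 3 (1.40 log units; beyond the scatter) and a 25-fold higher number from compound 2 to compound 3 (1.40 log units; beyond the scatter) both set it well apart from the other two compounds, whose own values differ only within the scatter: no change at the digits printed from compound 1 to compound 2 (within the scatter).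

Compound 4 `CC(C)(C)C(=O)NCCCCN1CCN(c2ccc(F)cc2)CC1` differs from compound 3 by fluoro in place of methoxy on an aromatic carbon. Within the data shown here, the one measured step that bears on this is a 25-fold higher number from compound 2 to compound 3 (1.40 log units; beyond the scatter), in which a halogen on that same aromatic carbon gave way to methoxy. Going from compound 3 to compound 4 reverses that exchange, though with a different halogen, so a large step toward lower numbers is expected: a 13-fold lower number from compound 3 to compound 4 (1.10 log units; beyond the scatter). Nothing measured here shows whether fluoro behaves like chloro, so the range is kept wide. Compound 4 is therefore estimated at 25 nM, between 8 nM and 80 nM.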

Compound 4, inhibition constant: 126 nM
Estimate against measurement, compound 4: 5.0-fold (0.70 log units) below; the whole stated range lies below it.
By their numbers in this assay, from the lowest: compounds 1 and 2 (each within the scatter of the next); then compound 4; then compound 3.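

On the aromatic carbon para to a large group, the identity of the halogen matters: a 10-fold higher number from compound 2 to compound 4 (1.00 log units; beyond the scatter) shows that fluoro in place of chloro does not preserve the number seen with chloro. Fluoro in place of methoxy gives only a partial return toward that number, with a 2.5-fold lower number from compound 3 to compound 4 (0.40 log units; beyond the scatter), so in this assay this position separates fluoro from both chloro and methoxy. The 4-fluorophenyl group also falls short of the 2-methoxyphenyl group, with a 10-fold higher number from compound 1 to compound 4 (1.00 log units; beyond the scatter). Nothing available here accounts for the difference between the two halogens.

The compounds shown leave open where bromo, methyl or trifluoromethyl on the same carbon would fall relative to fluoro and chloro. They also leave open whether this order would hold with a longer chain in the shared core.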